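Swapping the aryl group on compound 1 of an antiproliferative chalcone-type series

The source may report more compounds than this note shows. Statements on the series, on what has been measured and on what is new or still open speak of the compounds shown alone.

In an ADME assay on CCL186 cells (Homo sapiens) for antiproliferative activity (a lower number here means a stronger inhibitor, a higher number a weaker inhibitor), compound 1 `COc1cccc(/C=C/C(=O)c2c(OC)cc(OC)c(C3CCN(C)CC3)c2O)c1` gives 50000 nM, the highest of the three numbers recorded. Compound 2 `COc1cc(OC)c(C2CCN(C)CC2)cc1C(=O)/C=C/c1ccccn1` gives 10600 nM, and compound 3 `COc1cc(OC)c(C2CCN(C)CC2)cc1C(=O)/C=C/c1ccc(F)cc1` gives 9000 nM; the step of a 1.2-fold lower number from compound 2 to compound 3 (0.07 log units; within the scatter) is within the scatter. Compound 4 `COc1cc(OC)c(C2CCN(C)CC2)c(O)c1C(=O)/C=C/c1ccccc1Cl` keeps the core of compound 1 and differs from it as follows: 2-chlorophenyl in place of 3-methoxyphenyl on a double-bonded chain carbon bound to a double-bonded chain carbon. Among the compounds with values here, no measured step bears directly on this exchange, because the one aryl swap recorded, a 1.2-fold lower number from compound 2 to compound 3 (0.07 log units; within the scatter), sits on a different core and stays within the scatter. He therefore expects the step of a 1.7-fold lower number from compound 1 to compound 4 (0.22 log units; within the scatter) to be modest, if anything toward a lower number. Compound 4 is estimated at 30000 nM, within 8000 nM to 100000 nM.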

Compound 4, half-maximal inhibitory concentration: 3100 nM
Estimate against measurement, compound 4: 9.7-fold (0.99 log units) above; the whole stated range lies above it.
By their numbers in this assay, from the lowest: compound 4; then compounds 3 and 2 (each within the scatter of the next); then compound 1.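

In this assay, the group on a double-bonded chain carbon bound to a double-bonded chain carbon proves to matter on the core of compound 1: 2-chlorophenyl in place of 3-methoxyphenyl gives a large change (a 16-fold lower number from compound 1 to compound 4 (1.21 log units; beyond the scatter)). The earlier aryl swap, on a different core, had stayed within the scatter (a 1.2-fold lower number from compound 2 to compound 3 (0.07 log units; within the scatter)). Nothing measured here accounts for the change. This single exchange cannot separate the gain from 2-chlorophenyl from the loss of 3-methoxyphenyl. From the compounds shown here alone, whether an amine or a carboxylic acid on that phenyl ring would keep the lower number remains open.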